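The source may hold more compounds than are shown below. What is called first, only, known or untested is meant among the compounds shown, and "the series" means these compounds.

The measured compounds, each tested in an ADME assay on J774 cells (Mus musculus) for cytotoxicity; a higher number here means that more compound is needed for the effect, a lower number that less compound is needed:
Compound 1, `CCCCc1cc2c(=O)c(C#N)c[nH]c2cc1OCCOc1ccccc1`, gives only a limit of the assay, > 20000 nM.
Compound 2, `COC(=O)c1c[nH]c2ccccc2c1=O`, gives only a limit of the assay, > 20000 nM.
Compound 3, `COC(=O)c1c[nH]c2ccc(Oc3ccccc3)cc2c1=O`, gives only a limit of the assay, > 20000 nM.

So compound 1 does not stand at a number in this assay but at a limit, and the two other values shown are limits as well. Going by the values given here, the one step between measured compounds that differ in one place, a step that the two limits leave unreadable from compound 2 to compound 3, phenoxy in place of hydrogen on an aromatic carbon, has no readable size, since both of its ends rest on (the limit of > 20000 nM in this assay, at which 3 of the 3 values shown sit).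

The compound not yet measured is compound 4, `CCCCc1cc2c(=O)c(C(=O)NCC)c[nH]c2cc1OCCOc1ccccc1`. It differs from compound 1 in one place: ethylcarbamoyl in place of cyano on an aromatic carbon. Among the compounds with values here, none of the measured steps touches this change, and the only measured step offers no size at all, so there is nothing here that would point to a shift in either direction. The expectation for compound 4 is therefore simply that it stays where compound 1 stands, with a step that the limit leaves unreadable from compound 1 to compound 4 that is expected to show nothing beyond the scatter, and most likely another limit. Compound 4 is estimated at 30000 nM, within 10000 nM to 100000 nM.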

Compound 4, half-maximal effective concentration: > 20000 nM
Compound 4 ended at the assay's limit; the forecaster's own chance of this, stated with the estimate: 80%; the middle value lies beyond the limit too.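

No step can be read between compound 1 and compound 4, which differ by ethylcarbamoyl in place of cyano on an aromatic carbon, since both rest on the same limit and not on a number: the limit of > 20000 nM in this assay, at which 4 of the 4 values shown sit.

The compounds shown leave open at what concentration any of them would reach the effect in this assay, and whether this change shifts that concentration at all.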